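The source may report more compounds than this note shows. Statements on the series, on what has been measured and on what is new or still open speak of the compounds shown alone.

Among the compounds with values here, compound 2 `CC(C)(C)[Si](C)(C)OC[C@H]1O[C@@H](n2cnc3ccccc32)[C@H](O[Si](C)(C)C(C)(C)C)[C@]12OS(=O)(=O)C=C2N` is the only compound of the pair measured so far that gives a number in a functional assay on MT4 cells (Homo sapiens) for cytotoxicity (a lower number here means that less compound is tolerated, a higher number that more compound is tolerated), where compound 2 gives 15000 nM. Compound 1 `Cn1cnc2c(ncn2[C@@H]2O[C@H](CO[Si](C)(C)C(C)(C)C)[C@@]3(OS(=O)(=O)C=C3N)[C@H]2O[Si](C)(C)C(C)(C)C)c1=O` reaches only the limit of this assay, at which compound 1 gives > 150000 nM, a limit and not a number. Within the data shown here, the one measured step, an at least 10-fold lower number from compound 1 to compound 2 (1.00 log units; beyond the scatter), is the only guide available, and the limit of > 150000 nM in this assay, at which 1 of the 2 values shown sits, means its true size is known only as a lower bound.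

Compound 3 `CC(C)(C)[Si](C)(C)OC[C@H]1O[C@@H](n2c(=O)[nH]c(=O)c3[nH]cnc32)[C@H](O[Si](C)(C)C(C)(C)C)[C@]12OS(=O)(=O)C=C2N` differs from compound 2 by a group of 11 heavy atoms (5 carbon, 4 nitrogen, 2 oxygen; one five-membered aromatic ring with 2 hetero atoms, one six-membered aromatic ring with 2 hetero atoms) in place of a group of 9 heavy atoms (7 carbon, 2 nitrogen; one five-membered aromatic ring with 2 hetero atoms, one six-membered aromatic ring of carbon only), on a saturated ring carbon. This change runs opposite in kind to the measured step: it removes the benzimidazol-1-yl group that came in from compound 1 to compound 2 and returns a base bearing the same count of ring hetero atoms as compound 1. Because an at least 10-fold lower number from compound 1 to compound 2 (1.00 log units; beyond the scatter) was at least modest, the step back is expected to be of similar size in the other direction, giving a higher number for compound 3, with a 6.7-fold higher number from compound 2 to compound 3 (0.82 log units; beyond the scatter) as the expected step. Compound 3 is therefore estimated at 100000 nM, within 25000 nM to 200000 nM, with a fair chance that only a limit is reported.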

Compound 3, half-maximal cytotoxic concentration: 14000 nM
For compound 3 the middle estimate is 7.1-fold (0.85 log units) above the measured one; the whole stated range lies above it.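

In this assay, putting the entering group in place of 1H-benzimidazol-1-yl on this saturated ring carbon gives a 1.1-fold lower number from compound 2 to compound 3 (0.03 log units; within the scatter), so two groups that differ in heavy atoms, ring hetero atoms and hydrogen-bond donors cannot be told apart in this read-out. Compound 3 matches compound 1 in the heavy-atom count of this group and in its ring types, yet the read-out shows an at least 10-fold lower number from compound 1 to compound 3 (1.02 log units; beyond the scatter), so neither the size of the group nor its ring types alone sets the number across these three compounds. The value of compound 1 is a limit and not a number, which leaves the size of that step known only as a lower bound: the limit of > 150000 nM in this assay, at which 1 of the 3 values shown sits.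

Going by these compounds, what in the group of compound 1 separates it from the groups of compound 2 and compound 3 stays open. Also open, on these data alone, is whether an amine or a single ring such as imidazol-1-yl on this carbon would give a number close to those of compound 2 and compound 3, or a limit like that of compound 1.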